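Trifluoromethyl for methyl on the benzoyl ring of compound 2

A few compounds are considered here, and "the series" means these few. Any claim that something is new, unique, unknown or untested is made for them only; others in the source may bear on it.

Of the compounds shown here, three sharing one core have been measured in an ADME assay on HEK-293T cells (Homo sapiens) for cytotoxicity, read by MTT assay, with a stated time of 24 h; on this read-out higher numbers stand for lower toxicity in this test and lower numbers for higher toxicity in this test. Compound 1 `Cc1ccc(-c2nn(-c3ccccc3)cc2-c2nc3ccccc3n2C(=O)c2ccc(Cl)cc2)cc1` gives 216000 nM, compound 2 `Cc1ccc(-c2nn(-c3ccccc3)cc2-c2nc3ccccc3n2C(=O)c2cccc(C)c2)cc1` gives 195000 nM, and compound 3 `Cc1ccc(C(=O)n2c(-c3cn(-c4ccccc4)nc3-c3ccc(C)cc3)nc3ccccc32)cc1` gives 176000 nM. Compound 2 stands among these three with no separation that the assay can resolve: the step of a 1.1-fold lower number from compound 1 to compound 2 (0.04 log units; within the scatter) and the step of a 1.1-fold lower number from compound 2 to compound 3 (0.04 log units; within the scatter) both fall within the scatter, as does a 1.2-fold lower number from compound 1 to compound 3 (0.09 log units; within the scatter). On the numbers shown, the three compounds are indistinguishable in this assay.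

Compound 4 `Cc1cccc(C(=O)n2c(-c3cn(-c4ccccc4)nc3-c3ccc(C(F)(F)F)cc3)nc3ccccc32)c1` has not yet been measured. It differs from compound 2 by trifluoromethyl in place of methyl on an aromatic carbon, the trifluoromethyl entering para to a large group on a six-membered aromatic ring of carbon only. Going by the values given here, none of the measured steps involves a trifluoromethyl, so the closest guide is that exchanging substituents on the rings attached to the carbonyl carbon, or methyl for chloro on an aromatic carbon, moved the numbers only within the scatter in this assay. The expected step of a 1.1-fold lower number from compound 2 to compound 4 (0.02 log units; within the scatter) is therefore small, with no direction beyond the scatter. The value for compound 4 in this assay is estimated at 185000 nM, with a range from 95000 nM to 360000 nM.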

Compound 4, half-maximal cytotoxic concentration: 154000 nM
Beside the measured number, compound 4's estimate is 1.2-fold (0.08 log units) above it; the range from low to high includes it.
By their numbers in this assay, from the lowest: compounds 4, 3, 2 and 1 (each within the scatter of the next).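

Up to this point, every step had changed the group on the carbonyl carbon or a substituent on its ring, while the 4-methylphenyl group stayed the same in compounds 1, 2 and 3. Changing 4-methylphenyl to 4-(trifluoromethyl)phenyl now tests that second site directly, and this assay shows a 1.3-fold lower number from compound 2 to compound 4 (0.10 log units; within the scatter). Going by these compounds alone, this site therefore accepts trifluoromethyl in place of methyl, with its three added fluorine atoms, without a difference that this assay can resolve, so the flat picture seen among the earlier compounds extends to a second part of the molecule. Nothing shown here bears on why the step is this small.

On these data alone, what remains open is whether any change at this site can move the number beyond the scatter, for example an amine, a carboxylic acid or a longer chain in place of the trifluoromethyl. As far as these compounds go, it is also open whether trifluoromethyl on the ring attached to the carbonyl carbon, or a change at both sites together, would read the same way in this assay.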